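Rearranged side chain from compound 3 to compound 4

The source may hold more compounds than are shown below. What is called first, only, known or untested is meant among the compounds shown, and "the series" means these compounds.

Values in a functional assay on CCRF-CEM cells (Homo sapiens) (on this read-out lower numbers stand for higher toxicity in this test and higher numbers for lower toxicity in this test), as measured:
- compound 1 `CCOC(=O)NC(=O)NC1=CS(=O)(=O)O[C@@]12[C@@H](CO[Si](C)(C)C(C)(C)C)O[C@@H](n1cc(C)c(=O)n(C)c1=O)[C@@H]2O[Si](C)(C)C(C)(C)C` gives 3000 nM
- compound 2 `Cc1cn([C@@H]2O[C@H](CO[Si](C)(C)C(C)(C)C)[C@@]3(OS(=O)(=O)C=C3NC(N)=O)[C@H]2O[Si](C)(C)C(C)(C)C)c(=O)n(C)c1=O` gives 4360 nM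
- compound 3 `COC(=O)CC(=O)NC1=CS(=O)(=O)O[C@@]12[C@@H](CO[Si](C)(C)C(C)(C)C)O[C@@H](n1cc(C)c(=O)n(C)c1=O)[C@@H]2O[Si](C)(C)C(C)(C)C` gives 29700 nM

Compound 3 stands highest of the three, with a 6.8-fold higher number from compound 2 to compound 3 (0.83 log units; beyond the scatter) and a 9.9-fold higher number from compound 1 to compound 3 (1.00 log units; beyond the scatter) both beyond the scatter. Compound 4 `COC(=O)C(=O)CNC1=CS(=O)(=O)O[C@@]12[C@@H](CO[Si](C)(C)C(C)(C)C)O[C@@H](n1cc(C)c(=O)n(C)c1=O)[C@@H]2O[Si](C)(C)C(C)(C)C` has the same atoms joined differently: ((methoxycarbonyl)carbonyl)methyl in place of ((methoxycarbonyl)methyl)carbonyl on an amine nitrogen in this assay terms, ((methoxycarbonyl)carbonyl)methyl in place of ((methoxycarbonyl)methyl)carbonyl on an amine nitrogen. Among the compounds with values here, no measured step makes this exchange. The two modest steps above are the nearest evidence, while a 1.5-fold higher number from compound 1 to compound 2 (0.16 log units; within the scatter) stays within the scatter. A modest move towards a lower number is therefore expected, though no step beyond the scatter remains possible. The estimated step is a 2.5-fold lower number from compound 3 to compound 4 (0.39 log units; beyond the scatter) in this series. The expected value for compound 4 is 12000 nM with an estimated range from 3500 nM to 40000 nM overall.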

Compound 4, half-maximal cytotoxic concentration: 5570 nM
Compound 4: middle estimate off by 2.2-fold (0.33 log units), on the high side, within the range that was stated.
By their numbers in this assay, from the lowest: compounds 1, 2 and 4 (each within the scatter of the next); then compound 3.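

In this assay rearranging the same atoms from ((methoxycarbonyl)methyl)carbonyl to ((methoxycarbonyl)carbonyl)methyl on the amine nitrogen gives a 5.3-fold lower number from compound 3 to compound 4 (0.73 log units; beyond the scatter) and so shows that at this place the arrangement of the side chain matters, not only its atom content. Compound 4 lies within the scatter of the two urea-type compounds, with a 1.3-fold higher number from compound 2 to compound 4 (0.11 log units; within the scatter) and a 1.9-fold higher number from compound 1 to compound 4 (0.27 log units; within the scatter) and only compound 3 stands apart among the four. Nothing available here explains this shift. Open, on these data alone, is whether a carboxylic acid or a longer chain on this amine nitrogen would give a number like that of compound 3 or like that of compound 4.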